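A few compounds are considered here, and "the series" means these few. Any claim that something is new, unique, unknown or untested is made for them only; others in the source may bear on it.

Values in a functional assay on HEY cells (Homo sapiens) for cytotoxicity, read by MTT assay, with a stated time of 72 h; on this read-out higher numbers stand for weaker inhibition and lower numbers for stronger inhibition:
- compound 1 `N[C@H]1CC[C@H](Nc2c(C(=O)NCc3ccc(Cl)cc3)nc(Br)c3cccnc23)CC1`: 1000 nM
- compound 2 `N[C@H]1CC[C@H](Nc2c(C(=O)NCc3ccccn3)nc(Br)c3cccnc23)CC1`: > 20000 nM
- compound 3 `N[C@H]1CC[C@H](Nc2c(C(=O)NC3CCCCC3)nc(Br)c3cccnc23)CC1`: not yet measured

Compound 2 stands at > 20000 nM, which is a limit of the assay and not a number. Compound 3 carries cyclohexyl in place of (pyridin-2-yl)methyl on an amide-type nitrogen. Among the compounds with values here, the one measured step bearing on this is an at least 20-fold higher number from compound 1 to compound 2 (1.30 log units; beyond the scatter), large and beyond the scatter, with pyridin-2-yl in place of 4-chlorophenyl. Compound 3 no longer carries pyridin-2-yl, so movement toward lower numbers is expected, though it may stay at the limit. The expected step in this assay is an at least 4.0-fold lower number from compound 2 to compound 3 (0.60 log units; beyond the scatter). For compound 3 the estimated value is 5000 nM, with an expected range of 1500 nM to 20000 nM.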

Compound 3, half-maximal inhibitory concentration: 5200 nM
For compound 3 the middle estimate is 1.0-fold (0.02 log units) below the measured one; low and high end bracket the measured number.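

On the amide-type nitrogen, a cyclohexyl ring without an aromatic ring still gives a measured value in this assay, with an at least 3.8-fold lower number from compound 2 to compound 3 (0.58 log units; beyond the scatter). Compound 2 stands at a limit of the assay and not a number, so that step has no fixed size: the limit of > 20000 nM in this assay, at which 1 of the 3 values shown sits. Against the 4-chlorobenzyl group, cyclohexyl still gives a weaker result, with a 5.2-fold higher number from compound 1 to compound 3 (0.72 log units; beyond the scatter), so an aromatic ring is not required for a measured value, but 4-chlorobenzyl remains ahead here.

The compounds shown do not separate the effect of ring type from that of the chain carbon, since compound 3 differs from compound 2 in both. Cyclohexylmethyl or unsubstituted benzyl on the same nitrogen would address this.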